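Carbonate and ester glycol chains on a shared diisopropylphenyl core

The compounds below may be only part of what the source reports. "The series", "measured", "known", "first", "only" and "open" are said of these compounds alone.

Compound 1 `COCCOCCOCCOCCOCCOCCOC(=O)Oc1c(C(C)C)cccc1C(C)C`, compound 2 `COCCOCCOCCOC(=O)Oc1c(C(C)C)cccc1C(C)C` and compound 3 `COCCOCCOCCOCCOCCOCCOCCOCCOCCOCCOCC(=O)Oc1c(C(C)C)cccc1C(C)C` have been measured in an ADME assay on A549 cells (Homo sapiens) for cytotoxicity, read by MTT assay, with a stated time of 24 h; a higher number here means that more compound is needed for the effect, a lower number that less compound is needed. Compound 1 gives 730000 nM, compound 2 gives 2130000 nM and compound 3 gives 600000 nM. Between compound 1 and compound 2 the change is hydrogen in place of (2-(2-methoxyethoxy)ethoxy)methyl on a saturated chain carbon bound to an oxygen on a saturated carbon; this step reads a 2.9-fold higher number from compound 1 to compound 2 (0.47 log units; beyond the scatter). Compound 3 sits at the lowest number, but against compound 1 the gap lies within the scatter, so no order between those two is claimed; against compound 2 the gap lies beyond it. How the core of compound 3 differs from that of compound 1 is not broken down here. Compound 4 `COCCOCCOCCOCCOCCOCCOCCOCC(=O)Oc1c(C(C)C)cccc1C(C)C` is still to be measured in this assay. Its difference from compound 3 is hydrogen in place of (2-(2-methoxyethoxy)ethoxy)methyl on a saturated chain carbon bound to an oxygen on a saturated carbon, the same change as from compound 1 to compound 2. For compound 4 a step of a 2.5-fold higher number from compound 3 to compound 4 (0.40 log units; beyond the scatter) is expected, resting on the step of a 2.9-fold higher number from compound 1 to compound 2 (0.47 log units; beyond the scatter) seen for the identical change, giving an estimate of 1500000 nM, between 700000 nM and 3200000 nM.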

Compound 4, half-maximal effective concentration: 520000 nM
Compound 4: middle estimate off by 2.9-fold (0.46 log units), on the high side; the measured number lies below the stated range.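

In this assay hydrogen in place of (2-(2-methoxyethoxy)ethoxy)methyl, on a saturated chain carbon bound to an oxygen on a saturated carbon, gives a 1.2-fold lower number from compound 3 to compound 4 (0.06 log units; within the scatter) and so no readable shift on this core. The step therefore does not carry over from the core of compound 1 to the core of compound 3: the same change on two cores in this assay, a 2.9-fold higher number (0.47 log units; beyond the scatter) from compound 1 to compound 2 and a 1.2-fold lower number (0.06 log units; within the scatter) from compound 3 to compound 4, 3.4-fold (0.53 log units) apart, beyond the scatter of two such steps. With one pair on each core, this does not show what in the cores sets the two steps apart, and it gives no rule for a further core.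

Left open is how the same change reads on a longer chain, or on a chain carrying an amine or a carboxylic acid. From the compounds shown here alone, whether either step is typical of the series also stays open on these four compounds.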